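Solubility notes: aryl swap on the ring amide nitrogen

A few compounds are considered here, and "the series" means these few. Any claim that something is new, unique, unknown or untested is made for them only; others in the source may bear on it.

Of the compounds shown here, two have solubility numbers so far. Compound 2 `COc1ccc2[nH]c(C(=O)N3CC(=O)N(Cc4cccc(OC)n4)[C@@H](Cc4ccccc4)C3)cc2c1` gives 47500 nM in a physicochemical assay for solubility, read by spectrophotometry, in phosphate buffer, with a stated time of 2 h, at pH 7.4 (a higher number here means a more soluble compound, a lower number a less soluble compound), the higher of the two; compound 1 `COc1ccc2[nH]c(C(=O)N3CC(=O)N(Cc4ccccc4)[C@@H](COc4ccccc4)C3)cc2c1` gives 12200 nM in this assay, a gap that lies beyond the usual scatter. Compound 3 `COc1ccc2[nH]c(C(=O)N3CC(=O)N(c4ccccc4)[C@@H](Cc4ccccc4)C3)cc2c1` has not yet been measured. Relative to compound 2 it carries phenyl in place of (6-methoxypyridin-2-yl)methyl on an amide-type nitrogen in a ring. Among the measured compounds shown here, no measured pair differs in this one place, so the size of the step has no direct precedent; the nearest guide is compound 1, which also bears a benzyl group on the shared core and gives 12200 nM in this assay. The expected step of a 3.2-fold lower number from compound 2 to compound 3 (0.50 log units; beyond the scatter) is downward and beyond the scatter. Compound 3 is estimated at 15000 nM, with a range from 5000 nM to 45000 nM, to be checked against the measurement.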

Compound 3, solubility: 36100 nM
Compound 3: middle estimate off by 2.4-fold (0.38 log units), on the low side; low and high end bracket the measured number.
By their numbers in this assay, from the lowest: compound 1; then compounds 3 and 2 (each within the scatter of the next).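

In this assay, among the compounds shown here, the change on this amide-type nitrogen in a ring gives a 1.3-fold lower number from compound 2 to compound 3 (0.12 log units; within the scatter), the first direct reading at this position. Phenyl in place of (6-methoxypyridin-2-yl)methyl, an aromatic ring of carbon only in place of one with a hetero atom, therefore gives no difference that can be told from the scatter, at least with a benzyl group on the ring atom next to this nitrogen. No data on hand offer an explanation for this result.

As far as these compounds go, whether this position stays as flat with a carboxylic acid, an amine or a longer chain bearing either of them remains open. The same holds for whether the outcome depends on the benzyl group that stands on the neighbouring ring atom in both compound 2 and compound 3.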